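A few compounds are considered here, and "the series" means these few. Any claim that something is new, unique, unknown or untested is made for them only; others in the source may bear on it.

Compound 1 `O[C@H]1Cc2ccccc2C1NC1CCN(CCCc2c[nH]c3ccc(-n4cnnc4)cc23)CC1` and compound 2 `c1ccc(C2CCCCN2C2CCN(CCCc3c[nH]c4ccc(-n5cnnc5)cc34)CC2)cc1` were both tested in an assay on CHO cells for displacement of a labelled ligand from 5-hydroxytryptamine receptor 1D (Homo sapiens); on this read-out lower numbers stand for stronger inhibition and higher numbers for weaker inhibition. In this assay compound 1 gives 37 nM, the higher of the two numbers, while compound 2 gives 1.9 nM, a gap that lies beyond the usual scatter. Compound 3 `c1cc(CNC2CCN(CCCc3c[nH]c4ccc(-n5cnnc5)cc34)CC2)co1` has not been measured yet. It differs from compound 1 in one place: (furan-3-yl)methyl in place of 2-hydroxy-2,3-dihydro-1H-inden-1-yl on an amine nitrogen. Within the data shown here, no measured pair shows this exact change, so its size is uncertain. The expected step is a 2.2-fold higher number from compound 1 to compound 3 (0.33 log units; beyond the scatter), towards a somewhat higher number. Compound 3 is therefore estimated at 80 nM, within a range from 20 nM to 320 nM.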

Compound 3, half-maximal inhibitory concentration: 4.5 nM
Beside the measured number, compound 3's estimate is 18-fold (1.25 log units) above it; the measured number lies below the stated range.
By their numbers in this assay, from the lowest: compound 2; then compound 3; then compound 1.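

In this assay, (furan-3-yl)methyl in place of 2-hydroxy-2,3-dihydro-1H-inden-1-yl on the amine nitrogen gives an 8.2-fold lower number from compound 1 to compound 3 (0.91 log units; beyond the scatter) here. The entering group has fewer heavy atoms and no hydrogen-bond donor, so in this pair neither the larger group nor its hydroxy hydrogen is required for a low number. Nothing at hand explains this step.

Several features change at once, so this single pair cannot show which one matters. Going by these compounds, whether the furan oxygen contributes remains open, and a benzyl group on the same amine nitrogen would give the direct comparison.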